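The source may report more compounds than this note shows. Statements on the series, on what has been measured and on what is new or still open speak of the compounds shown alone.

Measured compounds in a functional assay on CHO cells for positive allosteric modulation of metabotropic glutamate receptor 2 (Homo sapiens), with a stated time of 30 min; a higher number here means a larger maximal response, a lower number a smaller maximal response:

compound 1 `N#Cc1c(N2CCC(c3ccccc3)CC2)ccn(CC2CC2)c1=O` gives 309%
compound 2 `COc1ccccc1C1CCN(c2ccn(CC3CC3)c(=O)c2C#N)CC1` gives 265%
compound 3 `N#Cc1c(N2CCC(c3c(F)cccc3F)CC2)ccn(CC2CC2)c1=O` gives 291%

Compound 3 stands second highest of the three. It lies below compound 1 by a number 18 percentage points lower from compound 1 to compound 3 (beyond the scatter) and above compound 2 by a number 26 percentage points higher from compound 2 to compound 3 (beyond the scatter), both steps beyond the scatter. The drop from compound 1 to compound 2 is a number 44 percentage points lower from compound 1 to compound 2 (beyond the scatter), the largest change in the series.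

Compound 4 `N#Cc1c(N2CCC(c3cc(F)cc(F)c3)CC2)ccn(CC2CC2)c1=O` is not yet measured. Its difference from compound 3 is 3,5-difluorophenyl in place of 2,6-difluorophenyl on a saturated ring carbon. The two compounds carry the same atoms, joined differently, so the step is a shift of the two fluorine atoms around the same ring.

Among the measured compounds shown here, of the measured steps, the one from compound 1 to compound 3 bears most closely on this, since it introduced the 2,6-difluorophenyl and cost a modest amount, a number 18 percentage points lower from compound 1 to compound 3 (beyond the scatter). The step from compound 2 to compound 3 shows that the 2,6-difluorophenyl variant sits between the phenyl and the 2-methoxyphenyl variants. For the measured compounds named here, no measured step compares two fluorine patterns against each other, so the direction is open. A small step in either direction, most likely within or near the scatter, is expected, a number 6 percentage points lower from compound 3 to compound 4 (within the scatter). Compound 4 is therefore estimated at 285%, with a range from 245% to 320%.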

Compound 4, largest response reached (Emax), in percent of the reference or control that the assay uses: 234%
Beside the measured number, compound 4's estimate is 51 percentage points above it; measured number outside the range, below it.
By their numbers in this assay, from the lowest: compound 4; then compound 2; then compound 3; then compound 1.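

In this assay, the placing of the two fluorine atoms on this ring counts for more than their presence: the shift alone gives a number 57 percentage points lower from compound 3 to compound 4 (beyond the scatter) (large), whereas bringing in the 2,6-difluorophenyl in place of phenyl gave only a number 18 percentage points lower from compound 1 to compound 3 (beyond the scatter) (modest). Among the compounds shown here, the 3,5-difluorophenyl also falls short of both non-fluorinated rings, with a number 31 percentage points lower from compound 2 to compound 4 (beyond the scatter) and a number 75 percentage points lower from compound 1 to compound 4 (beyond the scatter) (both large), so the series now shows that the substitution pattern on this ring, on a saturated ring carbon three ring bonds from the ring nitrogen, can outweigh the change of substituent itself, and all three substituted rings stand lower than the phenyl of compound 1, with no compound going against that. Nothing at hand explains why the two fluorine patterns part so widely.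

Open, on these data alone, is whether the loss comes from one of the two fluorine atoms or needs both, which a ring carrying a single fluorine would help to settle. Also open, as far as these compounds go, is whether a ring bearing an amine or a carboxylic acid would hold the maximal response near that of compound 1.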